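The source may hold more compounds than are shown below. What is called first, only, known or untested is meant among the compounds shown, and "the series" means these compounds.

Of the compounds shown here, three of one series have been measured in an assay (brain) for inhibition of Fatty-acid amide hydrolase 1 (Mus musculus), with stated times of 20 min and 15 min; a lower number here means a stronger inhibitor, a higher number a weaker inhibitor. Compound 1 `NC(=O)c1ccn(-c2cccc(OC(=O)NCCCCCCc3ccccc3)c2)c1` gives 0.6 nM, compound 2 `CCCCNC(=O)Oc1cccc(-c2oc(C)cc2C(N)=O)c1` gives 530 nM, and compound 3 `Cc1cc(C(N)=O)c(-c2cccc(OC(=O)NCCCCCCc3ccccc3)c2)o1` gives 1.7 nM. Among these three numbers compound 3 stands second highest: its nearest neighbour is compound 1, reached by a 2.8-fold higher number from compound 1 to compound 3 (0.45 log units; beyond the scatter), while its furthest is compound 2, from which a 310-fold lower number from compound 2 to compound 3 (2.49 log units; beyond the scatter).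

Compound 4 `Cc1oc(-c2cccc(OC(=O)NCCCCCCc3ccccc3)c2)cc1C(N)=O` is an unmeasured rearrangement of compound 3: the two share the same atoms, joined differently, the change being (4-carbamoyl-5-methylfuran-2-yl in place of 3-carbamoyl-5-methylfuran-2-yl on an aromatic carbon).

Going by the values given here, of the two measured steps, only the one from compound 1 to compound 3 concerns the five-membered ring carrying the carbamoyl group, and it was modest, a 2.8-fold higher number from compound 1 to compound 3 (0.45 log units; beyond the scatter). The step from compound 2 to compound 3 concerns the chain end and does not bear on the present change. Since a swap of the whole heteroaryl group moved the number only modestly, shifting the carbamoyl position within the furan of compound 3 is expected to give a modest step at most, with the direction uncertain but more likely towards a somewhat higher number, a 2.1-fold higher number from compound 3 to compound 4 (0.31 log units; beyond the scatter). Compound 4 is therefore expected to show about 3.5 nM in this assay, within a range from 0.8 nM to 15 nM.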

Compound 4, half-maximal inhibitory concentration: 18 nM
The estimate for compound 4 lay 5.1-fold (0.71 log units) below the measured number; measured number above the stated range.
By their numbers in this assay, from the lowest: compound 1; then compound 3; then compound 4; then compound 2.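

Compound 3 and compound 4 carry the same atoms and the same counts in their furan groups, yet in this assay exchanging 3-carbamoyl-5-methylfuran-2-yl for 4-carbamoyl-5-methylfuran-2-yl gives an 11-fold higher number from compound 3 to compound 4 (1.02 log units; beyond the scatter) as a large step. The earlier comparison, a 2.8-fold higher number from compound 1 to compound 3 (0.45 log units; beyond the scatter), was only modest and had left open how much the arrangement of the substituents on this heteroaryl group matters, whereas the new result shows that the place of the carbamoyl group on the furan can count for more than the exchange of the 3-carbamoyl-1H-pyrrol-1-yl group for the 3-carbamoyl-5-methylfuran-2-yl group. Against the lowest number of the series the new isomer also stands well apart, with a 30-fold higher number from compound 1 to compound 4 (1.48 log units; beyond the scatter) as a further large step.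

The compounds shown leave open whether the 4-carbamoyl arrangement would keep this cost with a carboxylic acid or a nitrile in place of the carbamoyl group, without the methyl group on the furan, or with the butyl chain of compound 2 at the carbamate nitrogen. Nothing measured alongside these numbers accounts for the difference between the two isomers.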